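Working notes: butyl in place of phenyl on compound 1

A few compounds are considered here, and "the series" means these few. Any claim that something is new, unique, unknown or untested is made for them only; others in the source may bear on it.

Measured in an ADME assay on L929 cells (Mus musculus, culture collection number NCTC 929) for cytotoxicity, read by MTT assay, with a stated time of 72 h; on this read-out lower numbers stand for stronger inhibition and higher numbers for weaker inhibition:
- Compound 1 `Cc1cc(O)c(C(=O)NCCCc2ccccc2)c(=O)o1`: 143000 nM
- Compound 2 `Cc1cc(O)c(C(=S)NC2CCCCC2)c(=O)o1`: 177000 nM
- Compound 3 `Cc1cc(O)c(CC2CCCCC2)c(=O)o1`: > 200000 nM, a limit of the assay

Going by the values given here, compound 1 at 143000 nM and compound 2 at 177000 nM lie within the scatter of each other, and these are the only two numbers available. Compound 4 `CCCCCCCNC(=O)c1c(O)cc(C)oc1=O` carries butyl in place of phenyl on a saturated chain carbon, three bonds along the chain from an amide-type nitrogen. Among the compounds with values here, no measured step bears on this change. In this assay the expected result is no shift beyond the scatter, and the estimated step of a 1.2-fold lower number from compound 1 to compound 4 (0.08 log units; within the scatter) has no firm direction. For compound 4 the estimated value is 120000 nM, with an expected range of 60000 nM to 200000 nM.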

Compound 4, half-maximal inhibitory concentration: 187000 nM
Beside the measured number, compound 4's estimate is 1.6-fold (0.19 log units) below it; low and high end bracket the measured number.
By their numbers in this assay, from the lowest: compounds 1, 2 and 4 (each within the scatter of the next). At a limit, above all of these: compound 3.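

In this assay, going by these compounds alone, the only measured step at this position, butyl in place of phenyl on a saturated chain carbon, three bonds along the chain from an amide-type nitrogen, reads a 1.3-fold higher number from compound 1 to compound 4 (0.12 log units; within the scatter). The phenyl ring on this chain is thus not required for a reading of this size, and the butyl chain serves equally within the scatter. Compound 3 remains a limit of the assay and gives no number to set against this step: the limit of > 200000 nM in this assay, at which 1 of the 4 values shown sits.

Still open, on these data alone, is whether an amine or a carboxylic acid at the chain end, or a longer chain, would move the number beyond the scatter.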